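Swapping Isobutyl for Cyclobutyl: Expected Clearance of Compound 3

The source may report more compounds than this note shows. Statements on the series, on what has been measured and on what is new or still open speak of the compounds shown alone.

Of the compounds shown here, two that share one core have been tested in an ADME assay on cells (Hepatocyte, Rattus norvegicus) for metabolic stability; a higher number here means faster removal of the compound, a lower number slower removal. Compound 1, `CC(C)n1cc(-c2ccnc3[nH]c(C4CCNCC4)cc23)ccc1=O`, gives < 1 uL/min, which is a limit of the assay rather than a number. Compound 2, `CC(C)Cn1cc(-c2ccnc3[nH]c(C4CCN(CC(=O)N(C)C)CC4)cc23)ccc1=O`, gives 6.6 uL/min in this assay. Among the compounds with values here, this is the only number obtained so far, because the other result is the limit of < 1 uL/min in this assay, at which 1 of the 2 values shown sits. Compound 3, `CN(C)C(=O)CN1CCC(c2cc3c(-c4ccc(=O)n(C5CCC5)c4)ccnc3[nH]2)CC1`, has not yet been measured. It differs from compound 2 in one place: cyclobutyl in place of isobutyl on an aromatic nitrogen. Within the data shown here, no measured pair shows what this kind of swap does in this assay, so there is nothing to lean on beyond the value of compound 2 itself. The step from compound 2 to compound 3 is therefore expected to stay within the usual scatter of the assay, neither clearly faster nor clearly slower: a 1.2-fold lower number from compound 2 to compound 3 (0.08 log units; within the scatter). Compound 3 is estimated at 5.5 uL/min, with a likely range from 2 uL/min to 14 uL/min.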

Compound 3, intrinsic clearance in a liver preparation (reported as CLH), per the amount of preparation that the assay uses: 5.8 uL/min
Beside the measured number, compound 3's estimate is 1.1-fold (0.02 log units) below it; the range from low to high includes it.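

Within the data shown here, the first measured swap at this position, on the aromatic nitrogen, gives a 1.1-fold lower number from compound 2 to compound 3 (0.06 log units; within the scatter) in this assay. In this pair, an open isobutyl chain and a cyclobutyl ring, each with 4 carbon atoms, cannot be told apart by this read-out, even though only the cyclobutyl group carries a ring. No measurement shown gives a reason for this result.

Compound 1 gives < 1 uL/min in this assay, which is a limit of the assay and not a number, and it differs from compound 2 in more than one place, so it adds nothing on this swap. Going by these compounds, whether this read-out stays in the same range with an amine, a carboxylic acid or a longer carbon chain on this nitrogen remains open.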